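The source may report more compounds than this note shows. Statements on the series, on what has been measured and on what is new or still open speak of the compounds shown alone.

In an ADME assay on L1210/0 cells (Mus musculus) for cytotoxicity, with a stated time of 48 h (a higher number here means a weaker inhibitor, a lower number a stronger inhibitor), compound 3 `C[S+]([O-])c1cn([C@H]2C[C@H](O)[C@@H](CO)O2)c(=O)[nH]c1=O` stands only at a limit, > 200000 nM. Compound 1 `O=c1[nH]c(=O)n([C@H]2C[C@H](O)[C@@H](CO)O2)cc1/C=C/I` gives 63900 nM and compound 2 `N#CSc1cn([C@H]2C[C@H](O)[C@@H](CO)O2)c(=O)[nH]c1=O` gives 78900 nM, with a 1.2-fold higher number from compound 1 to compound 2 (0.09 log units; within the scatter) separating them. The two steps that end at the limit are an at least 3.1-fold higher number from compound 1 to compound 3 (0.49 log units; beyond the scatter) and an at least 2.5-fold higher number from compound 2 to compound 3 (0.40 log units; beyond the scatter).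

Compound 4 `CCCc1cn([C@H]2C[C@H](O)[C@@H](CO)O2)c(=O)[nH]c1=O` has not yet been measured. It carries propyl in place of the group held by compound 3, on an aromatic carbon: a group of 3 heavy atoms (3 carbon; no ring) in place of a group of 3 heavy atoms (1 carbon, 1 oxygen, 1 sulfur; no ring), on an aromatic carbon. The measured steps bear on this change only indirectly. They replace other groups on that same carbon with the group of compound 3, and both are at least modest, so leaving that group may be expected to lower the number. Propyl itself has no measured neighbour, however, and the starting point gives no exact number, so the expectation stays loose. The expected change is an at least 2.0-fold lower number from compound 3 to compound 4 (0.30 log units; that floor lies within the scatter). Compound 4 is estimated at 100000 nM, within an expected range of 40000 nM to 200000 nM.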

Compound 4, half-maximal inhibitory concentration: > 200000 nM
Compound 4 ended at the assay's limit; the forecaster's own chance of this, stated with the estimate: 35%; at least 2.0-fold (0.30 log units) between middle value and limit.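

Propyl in place of cyanosulfanyl gives an at least 2.5-fold higher number from compound 2 to compound 4 (0.40 log units; beyond the scatter), and propyl in place of 2-iodoethenyl gives an at least 3.1-fold higher number from compound 1 to compound 4 (0.49 log units; beyond the scatter), in this assay. Until now only the group of compound 3 had raised the number at this position; propyl, with no hydrogen-bond acceptor against the one in that group, does the same, so among these compounds the acceptor count does not separate the higher numbers from the lower. The step from compound 3 to compound 4 cannot be read, because both compounds sit at a limit of the assay: the limit of > 200000 nM in this assay, at which 2 of the 4 values shown sit.

As far as these compounds go, whether compound 3 and compound 4 differ at all stays open. The compounds shown also leave open how an amine, a carboxylic acid or a longer chain on this carbon would compare with compound 1 and compound 2.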